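From fluoro to methoxy on the benzyl group

The compounds below may be only part of what the source reports. "The series", "measured", "known", "first", "only" and "open" are said of these compounds alone.

compound 1 `O[C@]1(Cc2cc(-c3cn[nH]c3)on2)CC[C@H](Cc2ccccc2)CC1`: 56.5 mL/min/kg
compound 2 `O[C@]1(Cc2cc(-c3cn[nH]c3)on2)CC[C@H](Cc2ccc(Cl)cc2)CC1`: 11.7 mL/min/kg
compound 3 `O[C@]1(Cc2cc(-c3cn[nH]c3)on2)CC[C@H](Cc2ccc(F)cc2)CC1`: 30 mL/min/kg

In an ADME assay on the whole organism (strain Sprague-Dawley) for pharmacokinetics, with Rattus norvegicus as the target, using cassette dosing (a lower number here means slower removal, a higher number faster removal of the compound), compound 3 gives 30 mL/min/kg. Two measured steps fix its place among the three numbers: a 1.9-fold lower number from compound 1 to compound 3 (0.27 log units; within the scatter), and a 2.6-fold higher number from compound 2 to compound 3 (0.41 log units; beyond the scatter).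

The next compound, compound 4 `COc1ccc(C[C@H]2CC[C@](O)(Cc3cc(-c4cn[nH]c4)on3)CC2)cc1`, keeps the core of compound 3 but carries methoxy in place of fluoro on an aromatic carbon, para to a large group (methoxy in place of fluoro on an aromatic carbon). For the measured compounds named here, no measured compound has a methoxy group, so the evidence is indirect. Three steps involve a change of substituent on that aromatic ring. Chloro in place of hydrogen gave a 4.8-fold lower number from compound 1 to compound 2 (0.68 log units; beyond the scatter), fluoro in place of hydrogen gave a 1.9-fold lower number from compound 1 to compound 3 (0.27 log units; within the scatter), and fluoro in place of chloro gave a 2.6-fold higher number from compound 2 to compound 3 (0.41 log units; beyond the scatter). These steps are modest at most, and none of them indicates a direction for methoxy. No shift beyond the scatter is therefore expected, although a modest move either way remains possible. The expected outcome is a 1.1-fold higher number from compound 3 to compound 4 (0.04 log units; within the scatter). Compound 4 is estimated at 33 mL/min/kg, with an expected range from 15 mL/min/kg to 65 mL/min/kg.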

Compound 4, clearance: 61.8 mL/min/kg
Estimate against measurement, compound 4: 1.9-fold (0.27 log units) below; measured number inside the range.
By their numbers in this assay, from the lowest: compound 2; then compounds 3, 1 and 4 (each within the scatter of the next, the first and the last beyond it).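

Where chloro on this ring brought the number down, methoxy in place of hydrogen gives a 1.1-fold higher number from compound 1 to compound 4 (0.04 log units; within the scatter) and so shows that in this assay a substituent at this place does not by itself go with a lower number. The identity of the substituent matters here: methoxy in place of fluoro gives a 2.1-fold higher number from compound 3 to compound 4 (0.31 log units; beyond the scatter) and methoxy in place of chloro gives a 5.3-fold higher number from compound 2 to compound 4 (0.72 log units; beyond the scatter) in a step about as large as the one chloro produced against hydrogen, which leaves compound 2 as the only one of the four whose steps to all the others lie beyond the scatter. The data hold nothing that explains why chloro and methoxy part in this way.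

On these data alone, whether the low number of compound 2 is particular to chloro or is shared by other groups at this place stays open, and bromo, trifluoromethyl or a nitrile there would speak to that. Nor do these compounds tell whether the result for methoxy extends to a longer ether such as ethoxy, or to a hydroxyl or an amine on the same carbon.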